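This account rests on a few compounds, and the source may have more. Where it says the series, first, only, none or still open, it means among the compounds named here.

Measured compounds:

Compound 1, `C[C@@H](NC(=O)[C@H](CCCNC(=N)N)NC(=O)c1ccc(CN(Cc2cccnc2)C(=O)c2ccc(F)cc2)cc1)c1cccc2ccccc12`, gives 45000 nM in an ADME assay on MT4 cells (Homo sapiens) for cytotoxicity; on this read-out lower numbers stand for higher toxicity in this test and higher numbers for lower toxicity in this test.
Compound 2, `C[C@@H](NC(=O)[C@H](CCCNC(=N)N)NC(=O)c1ccc(CN(Cc2ccncc2)C(=O)c2ccc(F)cc2)cc1)c1cccc2ccccc12`, gives 45000 nM in this assay.
Compound 3, `C[C@H](NC(=O)[C@H](CCCNC(=N)N)NC(=O)c1ccc(CN(Cc2ccc(F)cc2)Cc2cccnc2)cc1)c1cccc2ccccc12`, gives 41000 nM in this assay.

The three measured compounds sit close together in this assay, and none of their gaps reaches beyond the usual scatter, so no order among them can be read from these numbers. Compound 1 and compound 2 share one core, and compound 3 has a core whose difference from that of compound 1 is not broken down here. From compound 1 to compound 2 the change is pyridin-4-yl in place of pyridin-3-yl on a saturated chain carbon bound to an amide-type nitrogen, and the step it made in this assay was no change at the digits printed from compound 1 to compound 2 (within the scatter).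

Compound 4, `C[C@H](NC(=O)[C@H](CCCNC(=N)N)NC(=O)c1ccc(CN(Cc2ccncc2)Cc2ccc(F)cc2)cc1)c1cccc2ccccc12`, has not yet been measured. It arises from compound 3 by pyridin-4-yl in place of pyridin-3-yl on a saturated chain carbon bound to an amine nitrogen. Within the data shown here, this is the same kind of change as the one between compound 1 and compound 2, though the place differs: in the first pair the carbon carrying the ring is bound to an amide-type nitrogen, in the second pair to an amine nitrogen. Because the earlier step of no change at the digits printed from compound 1 to compound 2 (within the scatter) left the number essentially where it was, the step from compound 3 to compound 4 in this assay is expected to be likewise small, no change at the digits printed from compound 3 to compound 4 (within the scatter). Compound 4 is therefore estimated at 41000 nM, with a plausible range from 20000 nM to 85000 nM.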

Compound 4, half-maximal cytotoxic concentration: 44000 nM
The estimate for compound 4 lay 1.1-fold (0.03 log units) below the measured number; the range from low to high includes it.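

In this assay, the new step reads a 1.1-fold higher number from compound 3 to compound 4 (0.03 log units; within the scatter), so pyridin-4-yl in place of pyridin-3-yl on a saturated chain carbon bound to an amine nitrogen leaves compound 4 within the usual scatter of compound 3. Set beside the same exchange on the core of compound 1, where the carbon carrying the ring is bound to an amide-type nitrogen, the two steps agree: the same change on two cores in this assay, no change at the digits printed (within the scatter) from compound 1 to compound 2 and a 1.1-fold higher number (0.03 log units; within the scatter) from compound 3 to compound 4, 1.1-fold (0.03 log units) apart, within the scatter of two such steps. This shows that, in these two pairs, the exchange of one pyridine attachment for the other carried over from one core to the other as a step too small to read, but it does not show that the change has any real effect that transfers, since neither step rises out of the scatter, and two pairs say nothing about other cores or other read-outs.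

The compounds shown leave open whether a pyridin-2-yl ring or an unsubstituted phenyl ring on the same carbon would also stay within the scatter in this assay. They also leave open whether a step that does exceed the scatter, such as one from a primary amine or a carboxylic acid placed on that ring, would carry between these two cores in the same way.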